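A few compounds are considered here, and "the series" means these few. Any claim that something is new, unique, unknown or untested is made for them only; others in the source may bear on it.

Measured so far:
- Compound 1 `CN1CCN(CCCCn2c3c(c4ccccc42)C(=O)c2c[n+]([O-])c4ccccc4c2C3=O)CC1`: 100 nM
- Compound 2 `CC1(C)O[C@@H](CO)[C@H](Cn2cc(Cn3c4c(c5ccccc53)C(=O)c3c[n+]([O-])c5ccccc5c3C4=O)nn2)O1`: 690 nM

In a functional assay on MCF7 cells (Homo sapiens) for cytotoxicity, read by MTT assay, with a stated time of 72 h (on this read-out higher numbers stand for weaker inhibition and lower numbers for stronger inhibition), compound 1 gives 100 nM, the lower of the two numbers. Compound 2 gives 690 nM, and this gap lies beyond the usual scatter of repeated measurements. Compound 1 is therefore the stronger inhibitor of this pair.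

The next compound to be tested is compound 3 `O=C1c2c[n+]([O-])c3ccccc3c2C(=O)c2c1c1ccccc1n2CCCCN1CCCCC1`. It is built from compound 1 by one change: piperidin-1-yl in place of 4-methylpiperazin-1-yl on a saturated chain carbon, four bonds along the chain from an aromatic nitrogen. In plain words, piperidin-1-yl stands in place of 4-methylpiperazin-1-yl on a saturated chain carbon, four bonds along the chain from an aromatic nitrogen. The shared core stays the same.

Among the compounds with values here, no measured pair shows this swap, so the data give no direct guide to its size or direction. The best starting point is compound 1 at 100 nM, since only the end ring differs. The expected result is a 1.2-fold higher number from compound 1 to compound 3 (0.08 log units; within the scatter), a step no larger than the scatter, with no firm direction. Compound 3 is estimated at 120 nM, with an expected range from 40 nM to 360 nM.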

Compound 3, half-maximal inhibitory concentration: 150 nM
Estimate against measurement, compound 3: 1.3-fold (0.10 log units) below; the measured number falls inside the stated range.
By their numbers in this assay, from the lowest: compounds 1 and 3 (each within the scatter of the next); then compound 2.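

In this assay, putting piperidin-1-yl in place of 4-methylpiperazin-1-yl on a saturated chain carbon, four bonds along the chain from an aromatic nitrogen, gives a 1.5-fold higher number from compound 1 to compound 3 (0.18 log units; within the scatter), so the two compounds cannot be told apart on this read-out. Within the data shown here, this is the first direct look at this position, and it shows that the end ring can go from 2 hetero atoms to 1 hetero atom, and from 7 heavy atoms to 6, without a change that stands out from the usual scatter of repeated measurements. Nothing measured on these two end groups accompanies the result, so the pair stands as an observation with no explanation attached.

This single pair says little about end groups of other kinds, such as a morpholin-4-yl ring, an open-chain dimethylamino group or a carboxylic acid, any of which could behave differently at the end of the chain. Going by these compounds, the chain length also stays the same in compound 1 and compound 3, so the effect of a shorter or longer chain carrying either ring remains open.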